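Swapping the tail group on a potent dioxine-amide series

A few compounds are considered here, and "the series" means these few. Any claim that something is new, unique, unknown or untested is made for them only; others in the source may bear on it.

Measured so far:
- compound 1 `CCCCN1CCC(CNC(=O)c2cccc3c2OCCO3)CC1` in an assay on isolated protein for inhibition of 5-hydroxytryptamine receptor 4 (Homo sapiens) (a lower number here means a stronger inhibitor, a higher number a weaker inhibitor), gives 0.794 nM
- compound 2 `O=C(NCC1CCN(CCCS(=O)(=O)N2CCN(Cc3cccnc3)CC2)CC1)c1cccc2c1OCCO2` gives 0.159 nM
- compound 3 `CC1(C)CCN(S(=O)(=O)CCCN2CCC(CNC(=O)c3cccc4c3OCCO4)CC2)CC1` gives 0.126 nM

All three compounds share the same core, and they differ only in the chain that hangs from the ring nitrogen. Compound 2 stands with the second lowest number of the three, and its gap to compound 3 lies within the usual scatter, so the two cannot be told apart on these data. Compound 1, with a plain butyl chain, lies clearly higher.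

Within the data shown here, the one step that has been measured, a 6.3-fold lower number from compound 1 to compound 3 (0.80 log units; beyond the scatter), shows that adding a sulfonyl-linked ring to the chain brings a modest but real gain.

Compound 4 `CC(=O)N1CCN(S(=O)(=O)CCCN2CCC(CNC(=O)c3cccc4c3OCCO4)CC2)CC1` is the next variant. Its difference from compound 2 is acetyl in place of (pyridin-3-yl)methyl on an amine nitrogen in a ring. Among the measured compounds shown here, this change sits far out on the chain, on the second ring nitrogen, and no measured pair speaks to it directly. Since compound 2 and compound 3 carry quite different groups at this end yet give numbers within the scatter of each other, the change is expected to matter little, so the estimated step of a 1.3-fold higher number from compound 2 to compound 4 (0.10 log units; within the scatter) stays within the scatter. Compound 4 is therefore expected to give about 0.2 nM, likely between 0.08 nM and 0.5 nM.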

Compound 4, inhibition constant: 0.126 nM
Compound 4: the middle estimate sits 1.6-fold (0.20 log units) above what was measured, within the range that was stated.
By their numbers in this assay, from the lowest: compounds 3, 4 and 2 (each within the scatter of the next); then compound 1.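

In this assay, putting acetyl, with 3 heavy atoms and no ring, in place of (pyridin-3-yl)methyl, with 7 heavy atoms and a six-membered aromatic ring, on the amine nitrogen in a ring gives a 1.3-fold lower number from compound 2 to compound 4 (0.10 log units; within the scatter). So this position accepts either group with no readable effect on the number, and the aromatic ring of compound 2 is not needed to keep it in this range. The second new step, no change at the digits printed from compound 3 to compound 4 (within the scatter), with 4-acetylpiperazin-1-yl in place of 4,4-dimethylpiperidin-1-yl on a sulfonyl sulfur, shows that three different ring ends on the sulfonyl sulfur all give numbers within the scatter of their nearest neighbours, though nothing measured here bears on what lies behind this.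

The compounds shown leave open how a carboxylic acid, a free amine or a much longer chain at this far end would behave. They also leave open which part of the tail carries the gain in a 6.3-fold lower number from compound 1 to compound 3 (0.80 log units; beyond the scatter), the sulfonyl group or the ring beyond it, which a simple dimethylamino sulfonamide or an amide in place of the sulfonyl could help to separate.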